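Piperidine Replaced by a Carbamate: Expected Cytotoxicity

The compounds below may be only part of what the source reports. "The series", "measured", "known", "first", "only" and "open" are said of these compounds alone.

Compound 1 `O=C1O[C@@H](CN2CCCCC2)CN1c1ccc(-n2cc(-c3ccccn3)cn2)c(F)c1` carries a piperidin-1-yl group on a saturated chain carbon bound to a saturated ring carbon. In an ADME assay on HEK293-A cells (Homo sapiens) for cytotoxicity, read by MTT assay, with a stated time of 48 h (a lower number here means a stronger inhibitor, a higher number a weaker inhibitor), compound 1 gives > 400 ug/mL, which is a limit of the assay rather than a number. Compound 2 `O=C1O[C@@H](Cn2ccnc2)CN1c1ccc(-n2cc(-c3ccccn3)cn2)c(F)c1` likewise gives only a limit, > 400 ug/mL. Compound 3 `CCC(=O)NC[C@H]1CN(c2ccc(-n3cc(-c4ccccn4)cn3)c(F)c2)C(=O)O1` gives 389 ug/mL. Compound 1 therefore cannot be placed exactly; it stands at the limit of > 400 ug/mL in this assay, at which 2 of the 3 values shown sit. The step that the two limits leave unreadable from compound 1 to compound 2 cannot be read, and the step of an at least 1.0-fold lower number from compound 1 to compound 3 (0.01 log units; that floor lies within the scatter) stays within the usual scatter.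

Compound 4 `COC(=O)NC[C@H]1CN(c2ccc(-n3cc(-c4ccccn4)cn3)c(F)c2)C(=O)O1` differs from compound 1 by (methoxycarbonyl)amino in place of piperidin-1-yl on a saturated chain carbon bound to a saturated ring carbon. The step from compound 1 to compound 3 is the closest guide, since it also replaces piperidin-1-yl with a ring-free group carrying one hydrogen-bond donor, and it stayed within the scatter. No step beyond the scatter is therefore expected here. Compound 4 is expected to give about 400 ug/mL, within 280 ug/mL to 600 ug/mL. That estimate means an expected step of a number no higher from compound 1 to compound 4 (the limit leaves the size open), and the result may again come back only as a limit.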

Compound 4, half-maximal inhibitory concentration: 306 ug/mL
The estimate for compound 4 lay 1.3-fold (0.12 log units) above the measured number, and the stated range covers the measured number.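

Putting (methoxycarbonyl)amino on this saturated chain carbon gives the first sign of how far the group can change without a clear effect: the exchange for piperidin-1-yl gives an at least 1.3-fold lower number from compound 1 to compound 4 (0.11 log units; that floor lies within the scatter), and the exchange for 1H-imidazol-1-yl gives an at least 1.3-fold lower number from compound 2 to compound 4 (0.11 log units; that floor lies within the scatter). Methoxy in place of ethyl on a carbonyl carbon gives a 1.3-fold lower number from compound 3 to compound 4 (0.10 log units; within the scatter), so the propanoylamino and (methoxycarbonyl)amino chains cannot be told apart in this assay. Compounds 1 and 2 still give a limit of the assay rather than a number: the limit of > 400 ug/mL in this assay, at which 2 of the 4 values shown sit.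

As far as these compounds go, it remains open whether a primary amine, a carboxylic acid or a longer acyl chain at this place would move the number beyond the scatter. From the compounds shown here alone, the true size of any step starting from compound 1 or compound 2 also stays unknown.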